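Swapping a chlorinated thiazole for a bromophenyl on the sulfonyl

A few compounds are considered here, and "the series" means these few. Any claim that something is new, unique, unknown or untested is made for them only; others in the source may bear on it.

Three compounds share a core in which a sulfonyl group joins an aromatic ring to a piperidine nitrogen, and each was tested in a functional assay on HT-29 cells (Homo sapiens) for antiproliferative activity, read by CellTiter-Glo, with a stated time of 72 h; a lower number here means a stronger inhibitor, a higher number a weaker inhibitor. Compound 1, `Cc1nc(Cl)sc1S(=O)(=O)N1CCC(N2CCC(C)CC2)CC1`, gives 1.5 nM. Compound 2, `CC1CCN(C2CCN(S(=O)(=O)c3cccc4ccccc34)CC2)CC1`, gives 0.34 nM. Compound 3, `Cc1cc(C)c(S(=O)(=O)N2CCC(N3CCC(Cc4ccccc4)CC3)CC2)c(C)c1`, gives 3 nM. Compound 1 thus sits second highest of the three numbers: its gap to compound 3 lies within the usual scatter, while compound 2 sits clearly beyond it, at the lower end.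

Compound 4, `CC1CCN(C2CCN(S(=O)(=O)c3ccccc3Br)CC2)CC1`, has not yet been measured. It differs from compound 1 in one place: 2-bromophenyl in place of 2-chloro-4-methyl-1,3-thiazol-5-yl on a sulfonyl sulfur. For the measured compounds named here, no measured pair shows this exact exchange, so the expected step rests only on the spread among compounds 1, 2 and 3. Because compound 2 with its all-carbon aromatic ring gives 0.34 nM, a carbon-only ring on the sulfonyl seems compatible with a low number. Compound 4 is therefore expected to give 0.8 nM, with a likely range from 0.25 nM to 2.5 nM. The estimated step of a 1.9-fold lower number from compound 1 to compound 4 (0.27 log units; within the scatter) is a modest lowering, near the edge of the scatter.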

Compound 4, half-maximal inhibitory concentration: 3 nM
Beside the measured number, compound 4's estimate is 3.8-fold (0.57 log units) below it; the whole stated range lies below it.
By their numbers in this assay, from the lowest: compound 2; then compounds 1, 3 and 4 (each within the scatter of the next).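

In this assay, a 2.0-fold higher number from compound 1 to compound 4 (0.30 log units; within the scatter) shows that this place on the sulfonyl sulfur accepts a 2-bromophenyl group in place of the 2-chloro-4-methyl-1,3-thiazol-5-yl group, even though the ring's nitrogen and sulfur and the hydrogen-bond acceptors counted on the leaving group are gone. A carbon-only ring is also not enough on its own to give a number as low as that of compound 2, at 0.34 nM, since compound 4, which also has a carbon-only ring, gives 3 nM. Nothing available explains why the thiazole and bromophenyl compounds read alike.

On these data alone, it remains open how a 2-bromophenyl ring carrying an added amine or carboxylic acid would read. As far as these compounds go, it is also open whether this exchange would read the same on the different far end of the molecule found in compound 3.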